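A Nitro Group Replaces Trifluoromethyl: Lipophilicity Outlook

This account rests on a few compounds, and the source may have more. Where it says the series, first, only, none or still open, it means among the compounds named here.

Measured compounds:
compound 1, `O=C(Nc1ccc(F)cc1)c1ccc2cccc(O)c2n1`: 2.5
compound 2, `O=C(Nc1ccc(C(F)(F)F)cc1)c1ccc2cccc(O)c2n1`: 2.5

In a physicochemical assay for lipophilicity, read by HPLC (on this read-out higher numbers stand for higher lipophilicity and lower numbers for lower lipophilicity), compound 1 gives 2.5, and compound 2 gives 2.5. For the measured compounds named here, the single measured step, no change at the digits printed from compound 1 to compound 2 (within the scatter), shows that exchanging fluoro for trifluoromethyl on the aromatic carbon left the read-out level. Compound 2 therefore stands level with compound 1 at the digits shown, and nothing in the pair orders one above the other.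

Compound 3 `O=C(Nc1ccc([N+](=O)[O-])cc1)c1ccc2cccc(O)c2n1` has not yet been measured in this assay. It differs from compound 2 by nitro in place of trifluoromethyl on an aromatic carbon. Going by the values given here, the step from compound 1 to compound 2 is the only measured one at this position, and it bears on compound 3 only indirectly: it shows that a substituent exchange at this site can pass without a shift beyond the scatter, but no measured step involves a nitro group. Compound 3 is expected to come in somewhat lower, with an estimated step of a number 0.40 log units lower from compound 2 to compound 3 (beyond the scatter) relative to compound 2. For compound 3 the estimate in this assay is 2.1, with a range from 1.6 to 2.7.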

Compound 3, partition coefficient: 2.5
Estimate against measurement, compound 3: 0.40 log units below, within the range that was stated.
By their numbers in this assay, from the lowest: compounds 1, 2 and 3 (each within the scatter of the next).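

In this assay nitro in place of trifluoromethyl gives no change at the digits printed from compound 2 to compound 3 (within the scatter) and nitro in place of fluoro gives no change at the digits printed from compound 1 to compound 3 (within the scatter) on the same aromatic carbon of the six-membered ring, para to a large group. The earlier pair had shown a level read-out only for an exchange between two fluorine-bearing groups, whereas this result extends it to nitro, a group of nitrogen and oxygen that brings hydrogen-bond acceptors where trifluoromethyl has none, so that all three compounds now sit level at the digits printed and none can be ranked above another. Nothing available accounts for this level read-out.

The compounds shown leave open whether the read-out at this position would stay level with an amine, a carboxylic acid or a longer chain such as butyl, all of which differ more from the three groups compared so far. They also leave open whether nitro and trifluoromethyl would still read alike with a methoxy group in place of the hydroxyl on the shared core.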